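Compound 4: one free acid chain in a cytotoxic series

This account rests on a few compounds, and the source may have more. Where it says the series, first, only, none or still open, it means among the compounds named here.

Measured in a functional assay on MDA-MB-435S cells (Homo sapiens) for cytotoxicity, read by MTT assay (on this read-out lower numbers stand for stronger inhibition and higher numbers for weaker inhibition), so far
compound 1 `COc1ccc(-c2oc3c(CC=C(C)C)c(OCCOC(=O)CCC(=O)O)cc(O)c3c(=O)c2OCCOC(=O)CCC(=O)O)cc1` gives 60500 nM
compound 2 `COc1ccc(-c2oc3c(CC=C(C)C)c(OC(C(=O)O)C(=O)O)cc(O)c3c(=O)c2OC(C(=O)O)C(=O)O)cc1` gives 78900 nM
compound 3 `CCOC(=O)C(C)Oc1cc(O)c2c(=O)c(O)c(-c3ccc(OC)cc3)oc2c1CC=C(C)C` gives 2500 nM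

Compound 3 at 2500 nM holds the lowest of the three numbers in this assay and lies beyond the scatter from both others. Compound 4 `COc1ccc(-c2oc3c(CC=C(C)C)c(OC/C=C/C(=O)O)cc(O)c3c(=O)c2O)cc1` has not been measured. Its structure differs from that of compound 3 by 3-carboxyprop-2-en-1-yl in place of 1-(ethoxycarbonyl)ethyl on an oxygen on an aromatic ring.

For the measured compounds named here, no measured pair isolates this change, so the guide is loose. Compound 1 at 60500 nM and compound 2 at 78900 nM both carry free carboxy groups, but they differ from compound 4 in having two substituted oxygens. A moderate rise in this assay beyond the scatter is therefore expected, smaller than the gaps separating compound 3 from those two. The expected size of the change is a 4.8-fold higher number from compound 3 to compound 4 (0.68 log units; beyond the scatter) and it remains an estimate. The estimated value for compound 4 is 12000 nM (expected range 3500 nM to 45000 nM).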

Compound 4, half-maximal inhibitory concentration: 11300 nM
Compound 4: the middle estimate sits 1.1-fold (0.03 log units) above what was measured; low and high end bracket the measured number.
By their numbers in this assay, from the lowest: compound 3; then compound 4; then compounds 1 and 2 (each within the scatter of the next).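

In this assay, for the compounds shown here, this is the first single change that can be read: 3-carboxyprop-2-en-1-yl in place of 1-(ethoxycarbonyl)ethyl on an oxygen on an aromatic ring gives a 4.5-fold higher number from compound 3 to compound 4 (0.66 log units; beyond the scatter). The group on this oxygen therefore registers in the read-out, and with the rest of the molecule held constant, the step to a chain ending in a free carboxylic acid is modest. Nothing available explains the step.

The compounds shown leave open whether the rise goes with the free carboxylic acid, the extra double bond or the chain as a whole, as this step changes them together. An ethyl ester of the 3-carboxyprop-2-en-1-yl chain, or its saturated counterpart, on the same oxygen would separate these.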